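The source may report more compounds than this note shows. Statements on the series, on what has been measured and on what is new or still open speak of the compounds shown alone.

Compound 1 `O=C(/C(=C\c1ccc(Cl)cc1)Sc1ccc(Br)cc1)c1ccc(Br)cc1` was tested in a functional assay on DU-145 cells (Homo sapiens) for inhibition, read by trypan blue exclusion, with a stated time of 96 h (a higher number here means a weaker inhibitor of growth, a lower number a stronger inhibitor of growth), where compound 1 gives 1000 nM. Compound 2 `O=C(/C(=C\c1ccc(Br)cc1)SCc1ccc(Cl)cc1)c1ccc(Cl)cc1` gives 1000 nM in this assay, so compound 1 and compound 2 stand level at the digits shown and share the lowest number of the three measured. Within the data shown here, compound 3 `O=C(/C(=C\c1ccc(Cl)cc1)SCc1ccc(Cl)cc1)c1ccc(Br)cc1` gives 10000 nM in this assay; the only one-place step measured so far, a 10-fold higher number from compound 1 to compound 3 (1.00 log units; beyond the scatter), comes from putting 4-chlorobenzyl in place of 4-bromophenyl on a sulfur.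

Compound 4 `COc1cc(/C=C(/Sc2ccc(Br)cc2)C(=O)c2ccc(Br)cc2)ccc1O` differs from compound 1 at a different place: 4-hydroxy-3-methoxyphenyl in place of 4-chlorophenyl on a double-bonded chain carbon bound to a double-bonded chain carbon. Among the measured compounds shown here, the measured step concerns the group on the sulfur, not the ring on the double-bonded chain carbon, so no measured step bears directly on this change. With nothing to guide the direction, the expectation is a step no larger than the scatter, or at most a modest one, in either direction. Compound 4 is therefore expected to give about 2000 nM in this assay, within 500 nM to 10000 nM. That estimate amounts to an expected step of a 2.0-fold higher number from compound 1 to compound 4 (0.30 log units; within the scatter).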

Compound 4, concentration for 50% growth inhibition: 1000 nM
Estimate against measurement, compound 4: 2.0-fold (0.30 log units) above, and the stated range covers the measured number.
By their numbers in this assay, from the lowest: compounds 1, 2 and 4 (each within the scatter of the next); then compound 3.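

In this assay, putting 4-hydroxy-3-methoxyphenyl in place of 4-chlorophenyl gives no change at the digits printed from compound 1 to compound 4 (within the scatter), so this position takes a larger group that brings a hydrogen-bond donor and acceptors absent from the group it replaces, with no shift in the read-out. Among these compounds, the earlier one-place step changed the group on the sulfur and gave a 10-fold higher number from compound 1 to compound 3 (1.00 log units; beyond the scatter), so this is the first reading for the ring on the double-bonded chain carbon, and here the number holds. Nothing available explains why the number stays level at this position.

Still open, going by these compounds, is what a ring carrying only the hydroxy group or only the methoxy group would give, or one carrying an amine or a carboxylic acid. Also open, on these data alone, is whether this swap would leave the number level with the 4-chlorobenzyl group of compound 3 on the sulfur.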